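A few compounds are considered here, and "the series" means these few. Any claim that something is new, unique, unknown or untested is made for them only; others in the source may bear on it.

Measured compounds in a functional assay for inhibition, with Homo sapiens as the target; on this read-out lower numbers stand for stronger inhibition and higher numbers for weaker inhibition:
compound 1 `c1ccc(Nc2nccc(-c3ccncc3)n2)cc1`: 900 nM
compound 2 `CCc1cccc(Nc2nccc(-c3ccncc3)n2)c1`: 10600 nM
compound 3 `Cc1cccc(Nc2nccc(-c3ccncc3)n2)c1`: 8800 nM

Compound 3 stands second highest of the three numbers in this assay. Its nearest neighbour is compound 2: the pair shows a 1.2-fold lower number from compound 2 to compound 3 (0.08 log units; within the scatter), so the two cannot be told apart. Its furthest is compound 1, with a 9.8-fold higher number from compound 1 to compound 3 (0.99 log units; beyond the scatter).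

The next compound is compound 4 `CC(=O)Nc1cccc(Nc2nccc(-c3ccncc3)n2)c1`. Relative to compound 3 the change is acetamido in place of methyl on an aromatic carbon. Among the measured compounds shown here, two measured steps concern the same aromatic carbon: a 9.8-fold higher number from compound 1 to compound 3 (0.99 log units; beyond the scatter) and a 12-fold higher number from compound 1 to compound 2 (1.07 log units; beyond the scatter), both of which show that adding a small alkyl group there raised the number, while a 1.2-fold lower number from compound 2 to compound 3 (0.08 log units; within the scatter) shows no separation between methyl and ethyl. For the measured compounds named here, no measured compound carries an acetamido, or any group with a hydrogen-bond donor or acceptor, at this position, so none of the steps tests the new group directly. The only firm point is that compound 1, without a substituent there, gives 900 nM, and compound 3, with methyl, gives 8800 nM. For compound 4 a step of only modest size in this assay is expected, a 1.8-fold lower number from compound 3 to compound 4 (0.25 log units; within the scatter), with the direction uncertain. The estimate for compound 4 in this assay is 5000 nM, in the range 1200 nM to 20000 nM.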

Compound 4, half-maximal inhibitory concentration: 2700 nM
Estimate against measurement, compound 4: 1.9-fold (0.27 log units) above; the range from low to high includes it.
By their numbers in this assay, from the lowest: compound 1; then compound 4; then compounds 3 and 2 (each within the scatter of the next).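

In this assay this aromatic carbon now separates its substituents: acetamido gives a 3.3-fold lower number from compound 3 to compound 4 (0.51 log units; beyond the scatter) and a 3.9-fold lower number from compound 2 to compound 4 (0.59 log units; beyond the scatter), so it stands apart from both methyl and ethyl, which could not be told apart from each other. It still does not return to the level of the unsubstituted compound, with a 3.0-fold higher number from compound 1 to compound 4 (0.48 log units; beyond the scatter), so hydrogen keeps the lowest number of the four and each of the three groups shown at this place raises the number. The series therefore runs from hydrogen through acetamido to the two alkyl groups, but no supporting measurement bears on why acetamido falls where it does.

Going by these compounds, it remains open whether the difference from methyl and ethyl follows the carbonyl, the amide hydrogen or simply the larger group, and an amine, a methoxy group, a carboxylic acid or a longer amide chain at the same place would help separate these readings. On these data alone, whether acetamido gives the same result on the other carbons of this ring also remains open.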